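From carbamoyl to 3-fluorophenyl: compound 3

A few compounds are considered here, and "the series" means these few. Any claim that something is new, unique, unknown or untested is made for them only; others in the source may bear on it.

Going by the values given here, in an ADME assay on MT4 cells (Homo sapiens) for cytotoxicity, read by MTT assay, with a stated time of 5 days (a higher number here means that more compound is tolerated, a lower number that less compound is tolerated), compound 2 (`Cc1cc(C)c(Oc2cc(Nc3ccc(C#N)cc3)ncc2C(=O)NCc2cn(CC(N)=O)nn2)c(C)c1`) gives 24000 nM, the only true number so far. Compound 1 (`Cc1cc(C)c(Oc2cc(Nc3ccc(C#N)cc3)ncc2C(=O)NCc2cn(Cc3ccccc3Cl)nn2)c(C)c1`) gives >= 188000 nM, which is a limit of the assay. Compound 3 (`Cc1cc(C)c(Oc2cc(Nc3ccc(C#N)cc3)ncc2C(=O)NCc2cn(Cc3cccc(F)c3)nn2)c(C)c1`) carries 3-fluorophenyl in place of carbamoyl on a saturated chain carbon bound to an aromatic nitrogen. Among the compounds with values here, one measured step bears on this, at the same place: an at least 7.8-fold lower number from compound 1 to compound 2 (0.89 log units; beyond the scatter), with carbamoyl in place of 2-chlorophenyl, a change beyond the scatter. The new change runs the opposite way and brings in a different halogenated aryl group, so a rise of comparable size is expected in this assay, though the size of the measured step is known only as a limit. The expected change is a 3.5-fold higher number from compound 2 to compound 3 (0.55 log units; beyond the scatter). For compound 3 the estimate is 85000 nM, with an expected range from 28000 nM to 200000 nM.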

Compound 3, half-maximal cytotoxic concentration: >= 204000 nM
Compound 3: only a limit was reported; the forecaster's own chance of this, stated with the estimate: 40%; middle value at least 2.4-fold (0.38 log units) away from the limit.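

In this assay, 3-fluorophenyl in place of carbamoyl on a saturated chain carbon bound to an aromatic nitrogen gives an at least 8.5-fold higher number from compound 2 to compound 3 (0.92 log units; beyond the scatter). Compound 3 therefore ends at a limit of the assay and not at a number: the limit of >= 204000 nM in this assay, at which 1 of the 3 values shown sits. With compound 1 also at a limit, both aryl groups shown at this position lie on the same side of carbamoyl, which now stands as the only group here with a true number, and the step between compound 1 and compound 3 cannot be read.

Going by these compounds, how 2-chlorophenyl and 3-fluorophenyl compare therefore remains open. So does the question of whether a plain phenyl, a carboxylic acid or an amine at this place would follow the aryl groups or carbamoyl.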